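From an Amino Tail to a Benzoyloxy Tail

A few compounds are considered here, and "the series" means these few. Any claim that something is new, unique, unknown or untested is made for them only; others in the source may bear on it.

Of the compounds shown here, three sharing one core have been measured in a physicochemical assay for solubility, read by HPLC, with a stated time of 24 h; a higher number here means a more soluble compound, a lower number a less soluble compound. Compound 1 `CN(CCC#N)C[C@H]1CN(c2ccc(-n3cc(-c4ccccn4)cn3)c(F)c2)C(=O)O1` gives 64500 nM. Compound 2 `O=C1CCC(=O)N1C[C@H]1CN(c2ccc(-n3cc(-c4ccccn4)cn3)c(F)c2)C(=O)O1` gives 45300 nM, and compound 3 `CC(=O)OC[C@H]1CN(c2ccc(-n3cc(-c4ccccn4)cn3)c(F)c2)C(=O)O1` gives 373000 nM. Compound 1 therefore holds the second highest of the three numbers: the step of a 1.4-fold lower number from compound 1 to compound 2 (0.15 log units; within the scatter) stays within the scatter, while a 5.8-fold higher number from compound 1 to compound 3 (0.76 log units; beyond the scatter) lies beyond it, as does an 8.2-fold higher number from compound 2 to compound 3 (0.92 log units; beyond the scatter).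

Compound 4 `O=C(OC[C@H]1CN(c2ccc(-n3cc(-c4ccccn4)cn3)c(F)c2)C(=O)O1)c1ccccc1` has not yet been measured. It differs from compound 1 in one place: benzoyloxy in place of (2-cyanoethyl)(methyl)amino on a saturated chain carbon bound to a saturated ring carbon. The step that bears most on this change is a 5.8-fold higher number from compound 1 to compound 3 (0.76 log units; beyond the scatter), where an acetoxy group took the place of the same amino group on the same saturated chain carbon and the number rose. Benzoyloxy brings an additional six-membered aromatic ring of carbon only, which compound 3 lacks, so the full rise seen for compound 3 is not expected to repeat. The estimated step is a 1.7-fold higher number from compound 1 to compound 4 (0.23 log units; within the scatter), a modest rise. Compound 4 is expected to give about 110000 nM, with a range from 35000 nM to 350000 nM.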

Compound 4, solubility: <= 65400 nM
Compound 4: only a limit was reported; the forecaster's own chance of this, stated with the estimate: 5%; middle value at least 1.6-fold (0.22 log units) from the limit.
By their numbers in this assay, from the lowest: compounds 2 and 1 (each within the scatter of the next); then compound 3.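

In this assay, phenyl in place of methyl on a carbonyl carbon turns acetoxy into benzoyloxy and gives an at least 5.7-fold lower number from compound 3 to compound 4 (0.75 log units; beyond the scatter). Among the compounds shown here, the high number of compound 3 therefore does not extend to benzoyloxy on this saturated chain carbon, which the earlier compounds could not show, since acetoxy was the only group of its kind among them. Compound 4 is reported only as a limit, not as a number: the limit of <= 65400 nM in this assay, at which 1 of the 4 values shown sits.

Going by these compounds, the steps to compound 4 from compound 1 and from compound 2 cannot be read, so where benzoyloxy stands against those two groups remains open. A propionyloxy group, or a benzoyloxy group carrying an amine on its phenyl ring, could show whether the fall follows the phenyl ring itself or simply a larger group on that carbonyl carbon.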